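Chain amine swap and half-life in mouse microsomes

The source may hold more compounds than are shown below. What is called first, only, known or untested is meant among the compounds shown, and "the series" means these compounds.

Compound 2 `CC(C)N1C(=O)C(=O)N=C1/N=C(\NCCCN(C)C)Nc1ccc(Cl)c(Cl)c1`: > 1 h
Compound 1 `CCON/C(=N\C1=NC(=O)C(=O)N1C(C)C)Nc1ccc(Cl)c(Cl)c1`: > 1 h

In an in vitro ADME assay on microsomes from liver (Mus musculus) for metabolic stability, read by LC-MS (on this read-out higher numbers stand for a longer-lived compound and lower numbers for a shorter-lived compound), compound 2 gives > 1 h, which is a limit of the assay, not a number. Compound 1 likewise gives > 1 h, a limit. All that is known is the limit of > 1 h in this assay, at which 2 of the 2 values shown sit, so the step that the two limits leave unreadable from compound 1 to compound 2 cannot be sized. Compound 3 `CC(C)N1C(=O)C(=O)N=C1/N=C(\NCCCCN1CCCC1)Nc1ccc(Cl)c(Cl)c1` differs from compound 2 by (pyrrolidin-1-yl)methyl in place of dimethylamino on a saturated chain carbon, three bonds along the chain from an amine nitrogen. Among the compounds with values here, no measured step bears on this change, so neither a direction nor a size beyond the scatter can be expected; compound 3 is expected to sit near the limit again. Compound 3 is estimated at 1.5 h (range 0.5 h to 4 h), an expected step that the limit leaves unreadable from compound 2 to compound 3.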

Compound 3, half-life: > 1 h
Compound 3 ended at the assay's limit; the forecaster's own chance of this, stated with the estimate: 70%; the middle value lies beyond the limit too.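

No step among compound 1, compound 2 and compound 3 can be read, since all three sit at the same limit: the limit of > 1 h in this assay, at which 3 of the 3 values shown sit.

On these data alone, how long each compound actually lasts, and whether swapping the chain amine changes that, stays open.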